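A few compounds are considered here, and "the series" means these few. Any claim that something is new, unique, unknown or untested is made for them only; others in the source may bear on it.

In an ADME assay on J774 cells (Mus musculus) for cytotoxicity (on this read-out lower numbers stand for an effect already at smaller amounts and higher numbers for an effect only at larger amounts of compound), compound 3 `CCOc1ccc2[nH]cc(C(=O)OC)c(=O)c2c1` gives > 20000 nM, which is a limit and not a number. Compound 1 `CCCCc1ccc2[nH]cc(C(=O)OC)c(=O)c2c1` gives > 20000 nM, which is also a limit. The picture so far is therefore (the limit of > 20000 nM in this assay, at which 2 of the 3 values shown sit). Only compound 2 `COC(=O)c1c[nH]c2ccc(OCCc3ccccc3)cc2c1=O` gives a true number, 2200 nM.

Compound 4 `CCc1ccc2[nH]cc(C(=O)OC)c(=O)c2c1` keeps the shared core but has ethyl in place of ethoxy on an aromatic carbon. Within the data shown here, no measured step makes exactly this change. The nearest is the one between butyl and ethoxy, a step that the two limits leave unreadable from compound 1 to compound 3, so it shows no size. Among the measured compounds shown here, the only readable step is an at least 9.0-fold higher number from compound 2 to compound 3 (0.95 log units; beyond the scatter), and it concerns a phenyl group, which compound 4 lacks just as compound 3 does. Neither step points to a change here, so none beyond the scatter is expected, and the estimated step is a step that the limit leaves unreadable from compound 3 to compound 4. A report of only a limit is also the likeliest outcome. For compound 4 the estimated value is 22000 nM, with an expected range from 10000 nM to 40000 nM.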

Compound 4, half-maximal effective concentration: > 20000 nM
Compound 4: no number, only a limit (the forecaster's own chance of this, stated with the estimate: 75%); the middle value is on the limit's open side.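

Among these compounds, compound 1, compound 3 and compound 4 all give only a limit in this assay, so no step among them can be read. The compounds shown leave open whether butyl, ethoxy and ethyl on the aromatic carbon differ at all: the limit of > 20000 nM in this assay, at which 3 of the 4 values shown sit.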